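A few compounds are considered here, and "the series" means these few. Any claim that something is new, unique, unknown or untested is made for them only; others in the source may bear on it.

Compound 1 `Cc1cn2c(/C=N/NC(=N)N)c(-c3ccsc3)nc2s1`: 19500 nM
Compound 2 `N=C(N)N/N=C/c1c(-c2ccsc2)nc2sccn12`: 28800 nM

In a functional assay on cells (Cancer cell lines, Homo sapiens) for inhibition (on this read-out higher numbers stand for weaker inhibition of growth and lower numbers for stronger inhibition of growth), compound 2 gives 28800 nM and compound 1 gives 19500 nM. These two values lie within the scatter of each other, so the numbers do not rank the pair.

Compound 3 `Cc1cc(-c2nc3sccn3c2/C=N/NC(=N)N)c(C)s1` has not been measured yet. Within the data shown here, it has 2,5-dimethylthiophen-3-yl in place of thiophen-3-yl on an aromatic carbon, the one structural change from compound 2: 2,5-dimethylthiophen-3-yl in place of thiophen-3-yl on an aromatic carbon.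

Among the measured compounds shown here, only one measured step offers any guidance: a 1.5-fold higher number from compound 1 to compound 2 (0.17 log units; within the scatter). That step exchanges methyl for hydrogen on the shared core, not on the thiophene, so it is only indirect evidence. For the measured compounds named here, no measured pair changes the thiophene itself, and the data therefore give no firm direction. In this assay, a step no larger than the scatter is expected, though the uncertainty is wide. The expected step is a 1.4-fold lower number from compound 2 to compound 3 (0.16 log units; within the scatter). For compound 3 the estimated value is 20000 nM, with an expected range of 8000 nM to 50000 nM.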

Compound 3, concentration for total growth inhibition: 30200 nM
The estimate for compound 3 lay 1.5-fold (0.18 log units) below the measured number; measured number inside the range.
By their numbers in this assay, from the lowest: compounds 1, 2 and 3 (each within the scatter of the next).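

In this assay, replacing thiophen-3-yl with 2,5-dimethylthiophen-3-yl on the aromatic carbon gives a 1.0-fold higher number from compound 2 to compound 3 (0.02 log units; within the scatter). Among these compounds, the earlier step changed only a methyl on the shared core, so this is the first reading of a change to the thiophene itself: at this position, the group can grow from 5 to 7 heavy atoms with no difference that this read-out can resolve. No measurement here offers an explanation for this result.

The two methyl groups of compound 3 arrive together, so the shown compounds cannot tell whether each one alone would leave the number unchanged or whether two opposing contributions happen to cancel. On these data alone, it also remains open whether a ring without sulfur, such as phenyl or pyridine, or a thiophene carrying an amine or a carboxylic acid instead of methyl, would produce a step larger than the scatter.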